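Bromo to Chloro on the Aroyl Ring of Compound 1

A few compounds are considered here, and "the series" means these few. Any claim that something is new, unique, unknown or untested is made for them only; others in the source may bear on it.

Measured compounds:
compound 1, `Cc1ccc(S(=O)(=O)/C(=C/c2sccc2C)C(=O)c2ccc(Br)cc2)cc1`: 25000 nM
compound 2, `O=C(O)c1cc(/C=C(\C(=O)c2c(F)c(F)c(F)c(F)c2F)S(=O)(=O)c2ccc(Br)cc2)ccc1O`: > 100000 nM
compound 3, `CSc1ccc(/C=C(\C(=O)c2ccc(Br)cc2)S(=O)(=O)c2ccc(C)cc2)cc1`: 1000 nM

Three compounds share a core in which a sulfonyl-bearing chain carbon carries an aroyl group. In a functional assay on DU-145 cells (Homo sapiens) for inhibition, read by trypan blue exclusion, with a stated time of 96 h (a higher number here means a weaker inhibitor of growth, a lower number a stronger inhibitor of growth), compound 1 gives 25000 nM, the highest of the two plain numbers shown. For compound 2 the result is only a limit of the assay, > 100000 nM; the limit at the limit of > 100000 nM in this assay, at which 1 of the 3 values shown sits, is where this value sits. Within the data shown here, compound 3 gives 1000 nM, and the only measured step, a 25-fold lower number from compound 1 to compound 3 (1.40 log units; beyond the scatter), concerns the aryl group on the chain carbon and not the halogen of the aroyl ring.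

Compound 4, `Cc1ccc(S(=O)(=O)/C(=C/c2sccc2C)C(=O)c2ccc(Cl)cc2)cc1`, is not yet measured. It differs from compound 1 by chloro in place of bromo on an aromatic carbon. No measured step touches this halogen, so nothing shown bears directly on the change. Compound 4 is therefore expected to stay close to compound 1 in this assay, with a step of no change at the digits printed from compound 1 to compound 4 (within the scatter) that lies within the scatter. The estimate for compound 4 is 25000 nM, between 8000 nM and 80000 nM.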

Compound 4, concentration for 50% growth inhibition: 10000 nM
Compound 4: middle estimate off by 2.5-fold (0.40 log units), on the high side, and the stated range covers the measured number.
By their numbers in this assay, from the lowest: compound 3; then compound 4; then compound 1. At a limit, above all of these: compound 2.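

Among these compounds, the earlier compounds offered only one readable step, at the aryl group on the chain carbon, and said nothing about the halogen of the aroyl ring. Here, in this assay, chloro in place of bromo on an aromatic carbon, para to a large group, gives a 2.5-fold lower number from compound 1 to compound 4 (0.40 log units; beyond the scatter), so this position does register an exchange of one halogen for another, even with no ring, donor, acceptor or charge entering or leaving. The step is modest, far smaller than a 25-fold lower number from compound 1 to compound 3 (1.40 log units; beyond the scatter), and nothing measured here bears on why the chloro compound gives the lower number.

The compounds shown leave open whether chloro in place of bromo would give a like step with the 4-(methylsulfanyl)phenyl group of compound 3 on the chain carbon, as this halogen pair is read only with the 3-methylthiophen-2-yl group. They also leave open how this assay would read with other groups at this place on the aroyl ring, such as iodo, methoxy or a nitrile.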